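Ethoxy to butoxy: working notes on the series

This account rests on a few compounds, and the source may have more. Where it says the series, first, only, none or still open, it means among the compounds named here.

compound 1 `O=C(Nc1ccc(Cl)cc1)Nc1ncc([N+](=O)[O-])s1` gives > 1000000 nM in an ADME assay on Vero cells (Chlorocebus sabaeus) for cytotoxicity, read by sulforhodamine B assay, with a stated time of 48 h (on this read-out lower numbers stand for higher toxicity in this test and higher numbers for lower toxicity in this test), as a limit
compound 2 `CCOc1ccc(NC(=O)Nc2ncc([N+](=O)[O-])s2)cc1` gives > 1000000 nM in this assay as a limit

Compound 2 stands at the limit of > 1000000 nM in this assay, at which 2 of the 2 values shown sit, and offers no number. Compound 3 `CCCCOc1ccc(NC(=O)Nc2ncc([N+](=O)[O-])s2)cc1` differs from compound 2 by this change: ethyl in place of hydrogen on a saturated chain carbon, two bonds along the chain from an oxygen on an aromatic ring (ethoxy to butoxy). Going by the values given here, the only measured step bearing on it is a step that the two limits leave unreadable from compound 1 to compound 2 and it supplies no size to carry over. No step beyond the scatter is therefore expected in this assay and another limit is the likely report. The expected step is a number no higher from compound 2 to compound 3 (the limit leaves the size open) on this reading. For compound 3 the estimated value is 1000000 nM with an expected range from 300000 nM to 2000000 nM in the same assay conditions.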

Compound 3, half-maximal cytotoxic concentration: 58000 nM
Compound 3: middle estimate off by 17-fold (1.24 log units), on the high side; the whole stated range lies above it.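

Going from ethoxy to butoxy gives the first number of the series in this assay (an at least 17-fold lower number from compound 2 to compound 3 (1.23 log units; beyond the scatter)), so the chain on this oxygen can move the read-out towards higher toxicity in this test. Butoxy in place of chloro gives a step of the same printed size (an at least 17-fold lower number from compound 1 to compound 3 (1.23 log units; beyond the scatter)). Both steps are open-ended because compound 1 and compound 2 each stand at a limit and not at a number: the limit of > 1000000 nM in this assay, at which 2 of the 3 values shown sit.

Going by these compounds, whether a longer chain such as hexyloxy lowers the number further remains open. So does what an amine in place of the butoxy would give.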